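The compounds below may be only part of what the source reports. "The series", "measured", "known", "first", "only" and "open" are said of these compounds alone.

Compound 1, `CCS(=O)(=O)Nc1cc(-c2ccc3ncnc(Nc4ccc(OC(F)(F)F)cc4)c3c2)cnc1OC`, gives 6140 nM in a functional assay on SK-HEP1 cells (Homo sapiens) for cytotoxicity, read by sulforhodamine B assay, with a stated time of 72 h; a higher number here means a weaker inhibitor, a lower number a stronger inhibitor.
Compound 2, `CCS(=O)(=O)Nc1cc(-c2ccc3ncnc(Nc4ccc(OC)cc4)c3c2)cnc1OC`, gives 1610 nM in this assay.
Compound 3, `CCS(=O)(=O)Nc1cc(-c2ccc3ncnc(Nc4cccc(C(=O)OC)c4)c3c2)cnc1OC`, gives 2400 nM in this assay.

Among these three, compound 3 holds the second highest number. Its nearest neighbour is compound 2, with a 1.5-fold higher number from compound 2 to compound 3 (0.17 log units; within the scatter); its furthest is compound 1, with a 2.6-fold lower number from compound 1 to compound 3 (0.41 log units; beyond the scatter). The other measured step, a 3.8-fold lower number from compound 1 to compound 2 (0.58 log units; beyond the scatter), also concerns only the aryl group on the nitrogen.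

Compound 4, `COC(=O)c1cccc(Nc2ncnc3ccc(-c4cnc(OC)c(NS(=O)(=O)c5ccc(F)cc5F)c4)cc23)c1`, differs from compound 3 in a place none of these steps touch: 2,4-difluorophenyl in place of ethyl on a sulfonyl sulfur. The three measured compounds all share the ethylsulfonyl group, so nothing measured here speaks to what replacing it does in this assay. For the measured compounds named here, with no step bearing on the change, the expectation for compound 4 is an outcome close to compound 3, and the estimated step is a 1.1-fold lower number from compound 3 to compound 4 (0.04 log units; within the scatter), which is not expected to lie beyond the scatter in either direction. Compound 4 is therefore estimated at 2200 nM, with a range from 600 nM to 8000 nM to reflect the absence of any measured precedent for this change.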

Compound 4, half-maximal inhibitory concentration: 2800 nM
Compound 4: middle estimate off by 1.3-fold (0.10 log units), on the low side; measured number inside the range.
By their numbers in this assay, from the lowest: compounds 2, 3 and 4 (each within the scatter of the next); then compound 1.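

For the compounds shown here, until now every measured step concerned only the aryl group on the nitrogen, so this is the first reading at the sulfonyl sulfur. Placing 2,4-difluorophenyl, with its six-membered aromatic ring, where ethyl stood gives (a 1.2-fold higher number from compound 3 to compound 4 (0.07 log units; within the scatter)), so this assay cannot tell compound 3 and compound 4 apart, and this position takes the larger group with the 3-(methoxycarbonyl)phenyl group kept on the nitrogen. No measurement shown here gives a reason for this result.

The compounds shown leave open whether a longer chain such as butyl, or an amine on the sulfonyl sulfur, would read the same way. They also leave open whether 2,4-difluorophenyl on the sulfonyl sulfur would behave alike with 4-methoxyphenyl or 4-(trifluoromethoxy)phenyl on the nitrogen.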